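Nitro in Place of Trifluoromethyl on a Shared Core

The source may report more compounds than this note shows. Statements on the series, on what has been measured and on what is new or still open speak of the compounds shown alone.

Three measured compounds share one core and differ only at a single aromatic carbon. In an assay on HL-60 cells for inhibition of glutathione S-transferase P (Homo sapiens) (a higher number here means a weaker inhibitor, a lower number a stronger inhibitor), compound 1 `C=C(C)C(=O)c1ccc(OCc2nc(-c3ccccc3)no2)cc1C` gives 1970 nM. Compound 2 `C=C(C)C(=O)c1ccc(OCc2nc(-c3ccc(F)cc3)no2)cc1C` carries fluoro at that carbon, and in this assay compound 2 gives 3500 nM. Compound 3 `C=C(C)C(=O)c1ccc(OCc2nc(-c3ccc(C(F)(F)F)cc3)no2)cc1C` carries trifluoromethyl there, and in this assay compound 3 gives 3300 nM; this is the second highest of the three numbers, and the step of a 1.7-fold higher number from compound 1 to compound 3 (0.22 log units; within the scatter) as well as the step of a 1.1-fold lower number from compound 2 to compound 3 (0.03 log units; within the scatter) both lie within the scatter, as does a 1.8-fold higher number from compound 1 to compound 2 (0.25 log units; within the scatter). Compound 4 `C=C(C)C(=O)c1ccc(OCc2nc(-c3ccc([N+](=O)[O-])cc3)no2)cc1C` has not yet been measured. Its change from compound 3 is nitro in place of trifluoromethyl on an aromatic carbon. Going by the values given here, the steps that bear on this change are those that alter the same aromatic carbon, a 1.7-fold higher number from compound 1 to compound 3 (0.22 log units; within the scatter) and a 1.1-fold lower number from compound 2 to compound 3 (0.03 log units; within the scatter), and neither moved the number beyond the scatter. One therefore expects no step beyond the scatter in this assay for compound 4, namely a 1.1-fold lower number from compound 3 to compound 4 (0.04 log units; within the scatter). Compound 4 is estimated at 3000 nM, with a range from 1400 nM to 6500 nM.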

Compound 4, half-maximal inhibitory concentration: 2900 nM
The estimate for compound 4 lay 1.0-fold (0.01 log units) above the measured number; low and high end bracket the measured number.
By their numbers in this assay, from the lowest: compounds 1, 4, 3 and 2 (each within the scatter of the next).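

In this assay a fourth group at this aromatic carbon again leaves the number in place: the steps of a 1.1-fold lower number from compound 3 to compound 4 (0.06 log units; within the scatter) and a 1.2-fold lower number from compound 2 to compound 4 (0.08 log units; within the scatter) and also a 1.5-fold higher number from compound 1 to compound 4 (0.17 log units; within the scatter) all stay within the scatter. Unlike trifluoromethyl, nitro is counted with hydrogen-bond acceptors, yet this exchange produced no step beyond the scatter, so across these four compounds no substituent at this carbon separates from any other. Nothing available here accounts for how close these numbers lie. On these data alone, whether an amine, a carboxylic acid or a longer chain at this carbon would move the number beyond the scatter remains open. So does whether changes elsewhere on the shared core would have a larger effect in this assay than any seen here.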